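The compounds below may be only part of what the source reports. "The series", "measured", "known", "first", "only" and "open" are said of these compounds alone.

Working notes on the series.

Compound 1 `Cc1oc(-c2ccc(Cl)cc2)nc1CN1CCC(C(=O)NCCCN2C[C@H](C)C[C@H](C)C2)CC1` carries a 4-chlorophenyl on the shared core. In a physicochemical assay for solubility, in phosphate buffer, measured as kinetic solubility, at pH 7.4 (on this read-out lower numbers stand for lower solubility and higher numbers for higher solubility), compound 1 gives > 72 ug/mL, which is a limit of the assay and not a number. Compound 2 `Cc1ccccc1-c1nc(CN2CCC(C(=O)NCCCCN3C[C@H](C)C[C@H](C)C3)CC2)c(C)o1` in this assay gives > 71 ug/mL, again a limit. Compound 3 `Cc1ccccc1-c1nc(CN2CCC(C(=O)N3CCN(C4CCN(C)CC4)CC3)CC2)c(C)o1` in this assay gives > 71 ug/mL, also a limit. Compound 1 therefore stands only at a limit, and the two other measured compounds stand at limits too: the limit of > 71 ug/mL in this assay, at which 2 of the 3 values shown sit, and (the limit of > 72 ug/mL in this assay, at which 1 of the 3 values shown sits). Among the measured compounds shown here, no two measured compounds differ in one place, so no measured step can be sized, and nothing shows how a change on the shared core moves solubility.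

Compound 4 `Cc1cccc(C)c1-c1nc(CN2CCC(C(=O)NCCCN3C[C@H](C)C[C@H](C)C3)CC2)c(C)o1` is the next compound for this assay. It differs from compound 1 by 2,6-dimethylphenyl in place of 4-chlorophenyl on an aromatic carbon. A 2,6-dimethylphenyl enters where a 4-chlorophenyl leaves; donors, acceptors and charge are unchanged by the count.

With every measured value at a limit there is no basis for a sized step; the step of an at least 1.0-fold lower number from compound 1 to compound 4 (0.01 log units; that floor lies within the scatter) is expected to be none beyond the scatter. Compound 4 is expected to sit near the limit of this assay. The estimate for compound 4 is 70 ug/mL, with a range from 35 ug/mL to 100 ug/mL.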

Compound 4, solubility: 55.9 ug/mL
For compound 4 the middle estimate is 1.3-fold (0.10 log units) above the measured one; measured number inside the range.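

In this assay, among the compounds shown here, compound 4 gives 55.9 ug/mL, the only value shown that is a number and not a limit, so the aromatic carbon next to the ring nitrogen and next to the ring oxygen now has one readable value. Placing 2,6-dimethylphenyl there in place of 4-chlorophenyl gives an at least 1.2-fold lower number from compound 1 to compound 4 (0.10 log units; that floor lies within the scatter), which is the only one-place comparison in the series and fixes a floor but not a size, so it shows no change beyond the scatter and does not exclude a larger one. Compound 1 stands only at a limit, which is not a number: the limit of > 72 ug/mL in this assay, at which 1 of the 4 values shown sits.

How far the real gap lies beyond that floor stays unknown while one end of the step is a limit, and no other steps among the compounds shown can be read. Also open, going by these compounds, is whether a phenyl carrying a carboxylic acid or an amine at this position would give a number clearly apart from that of compound 4, and whether the same swap would read the same way on the longer chain of compound 2.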